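Working notes: methylcarbamoyl to propargylcarbamoyl

This account rests on a few compounds, and the source may have more. Where it says the series, first, only, none or still open, it means among the compounds named here.

Measured in an ADME assay on CEM-SS cells (Homo sapiens) for cytotoxicity, read by XTT assay, with a stated time of 6 days; on this read-out lower numbers stand for higher toxicity in this test and higher numbers for lower toxicity in this test:
- compound 1 `CCCC(=O)OCSc1ccccc1C(=O)NCC(N)=O`: > 100 uM (a limit)
- compound 2 `CCCC(=O)OCSc1ccccc1C(=O)NCCCC(N)=O`: 56.6 uM
- compound 3 `CCCC(=O)OCSc1ccccc1C(=O)NCC(=O)NC`: > 100 uM (a limit)

Compound 3 stands only at a limit, > 100 uM. This is the limit of > 100 uM in this assay, at which 2 of the 3 values shown sit.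

Compound 4 `C#CCNC(=O)CNC(=O)c1ccccc1SCOC(=O)CCC` differs from compound 3 by ethynyl in place of hydrogen on a saturated chain carbon bound to an amide-type nitrogen, which also reads as methylcarbamoyl to propargylcarbamoyl.

The nearest measured change, methyl in place of hydrogen on an amide-type nitrogen, gave a step that the two limits leave unreadable from compound 1 to compound 3. Changes on a saturated chain carbon bound to an amide-type nitrogen gave an at least 1.7-fold lower number from compound 1 to compound 2 (0.24 log units; that floor lies within the scatter) and an at least 1.7-fold higher number from compound 2 to compound 3 (0.24 log units; that floor lies within the scatter). No step beyond the scatter is therefore expected in this assay, and a further limit reading is plausible.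

The expected step is an at least 1.1-fold lower number from compound 3 to compound 4 (0.04 log units; that floor lies within the scatter).

For compound 4 the estimated value is 90 uM, with an expected range of 35 uM to 200 uM.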

Compound 4, half-maximal toxic concentration: 95.4 uM
The estimate for compound 4 lay 1.1-fold (0.03 log units) below the measured number; the range from low to high includes it.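

In this assay compound 4 gives a number rather than a limit, and ethynyl at this position shows an at least 1.0-fold lower number from compound 3 to compound 4 (0.02 log units; that floor lies within the scatter). Propargyl in place of hydrogen on the amide-type nitrogen shows an at least 1.0-fold lower number from compound 1 to compound 4 (0.02 log units; that floor lies within the scatter), while propargylcarbamoyl in place of 2-carbamoylethyl shows a 1.7-fold higher number from compound 2 to compound 4 (0.23 log units; within the scatter). The readings for compound 1 and compound 3 are limits, so the true size of the two steps from them stays open: the limit of > 100 uM in this assay, at which 2 of the 4 values shown sit.

On these data alone, whether an amine, a carboxylic acid or a longer chain in place of propargyl would give a step beyond the scatter remains open.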